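This account rests on a few compounds, and the source may have more. Where it says the series, first, only, none or still open, it means among the compounds named here.

Measured so far:
- Compound 1 `C=CCOc1ccc2c(=O)c(-c3cc(OC)c(OC)cc3OC)coc2c1`; in a functional assay on HUVEC cells (Homo sapiens) for antiproliferative activity, read by MTT assay, with a stated time of 24 h (on this read-out lower numbers stand for stronger inhibition and higher numbers for weaker inhibition), compound 1 gives > 10000 nM, which is a limit of the assay rather than a number.
- Compound 2 `COc1ccc2c(=O)c(-c3cc(OC)c(OC)cc3OC)coc2c1`; in this assay compound 2 gives > 10000 nM, again only a limit.
- Compound 3 `COc1cc(OC)c(-c2coc3cc(OCc4ccc(Br)cc4)ccc3c2=O)cc1OC`; in this assay compound 3 gives > 10000 nM, also a limit.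

Every value shown so far sits at the same limit: the limit of > 10000 nM in this assay, at which 3 of the 3 values shown sit. Compound 3 therefore stands nowhere that can be told apart from compound 1 or compound 2; only a limit is known for it, not a number. The three steps among the measured compounds all change the group on the saturated chain carbon bound to an oxygen on an aromatic ring, and none can be sized: a step that the two limits leave unreadable from compound 1 to compound 2, a step that the two limits leave unreadable from compound 1 to compound 3, a step that the two limits leave unreadable from compound 2 to compound 3.

Compound 4 `COc1cc(OC)c(-c2coc3cc(OCc4cccc(F)c4)ccc3c2=O)cc1OC` differs from compound 3 at that same place: 3-fluorophenyl in place of 4-bromophenyl on a saturated chain carbon bound to an oxygen on an aromatic ring. For the measured compounds named here, the steps that bear on it are those three unreadable ones, so neither a size nor a direction can be drawn from them; nothing measured suggests a move off the limit. The step expected is a step that the limit leaves unreadable from compound 3 to compound 4. Compound 4 is therefore estimated to remain at the limit in this assay, at about 15000 nM, within 5000 nM to 50000 nM.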

Compound 4, half-maximal inhibitory concentration: 5300 nM
Estimate against measurement, compound 4: 2.8-fold (0.45 log units) above, within the range that was stated.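

Compound 4, carrying 3-fluorobenzyl, is the only compound shown that gives a number rather than a limit in this assay, and this gives the place on a saturated chain carbon bound to an oxygen on an aromatic ring its first readable steps: an at least 1.8-fold lower number from compound 3 to compound 4 (0.27 log units; that floor lies within the scatter), an at least 1.8-fold lower number from compound 2 to compound 4 (0.27 log units; that floor lies within the scatter) and an at least 1.8-fold lower number from compound 1 to compound 4 (0.27 log units; that floor lies within the scatter). All three are floors, so they show that a change at this place can bring a value inside the range of the assay but do not fix the true size of the step, and the steps among compound 1, compound 2 and compound 3 cannot be read. The rest of the series stays at one limit: the limit of > 10000 nM in this assay, at which 3 of the 4 values shown sit.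

The change from 4-bromophenyl to 3-fluorophenyl alters both the halogen and its place on the ring, and the compounds shown do not separate the two, which 3-bromobenzyl or 4-fluorobenzyl at the same place would do. Also open, from the compounds shown here alone, is how this place responds to an unsubstituted benzyl, to a benzyl carrying an amine or a carboxylic acid, or to a longer chain such as 2-phenylethyl.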